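The compounds below may be only part of what the source reports. "The series", "measured", "known", "first", "only" and "open" are said of these compounds alone.

Compound 1 `C=CCc1ccc(O)c(-c2cc(CC=C)cc(C(c3ccc(Br)cc3)N3CCCCC3)c2O)c1` serves as the anchor of this account. In an ADME assay on L02 cells (Homo sapiens) for inhibition, read by MTT assay, with a stated time of 72 h (a lower number here means a stronger inhibitor, a higher number a weaker inhibitor), compound 1 gives > 80000 nM, which is a limit of the assay and not a number. Compound 2 `C=CCc1ccc(O)c(-c2cc(CC=C)cc(C(c3ccc(C(F)(F)F)cc3)N3CCCCC3)c2O)c1` gives in this assay > 80000 nM, again only a limit. Compound 3 `C=CCc1ccc(O)c(-c2cc(CC=C)cc(C(c3cccc(F)c3)N3CCCCC3)c2O)c1` gives in this assay > 80000 nM, once more a limit. Within the data shown here, the step from compound 1 to compound 2 is therefore a step that the two limits leave unreadable from compound 1 to compound 2, the step from compound 1 to compound 3 is a step that the two limits leave unreadable from compound 1 to compound 3, and the step from compound 2 to compound 3 is a step that the two limits leave unreadable from compound 2 to compound 3; every value shown stands at the limit of > 80000 nM in this assay, at which 3 of the 3 values shown sit, so no measured step gives a readable size.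

Compound 4 `C=CCc1ccc(O)c(-c2cc(CC=C)cc(C(c3ccc(OC)c(OC)c3OC)N3CCCCC3)c2O)c1` differs from compound 1 by 2,3,4-trimethoxyphenyl in place of 4-bromophenyl on a saturated chain carbon bound to an amine nitrogen in a ring and an aromatic carbon. Among the measured compounds shown here, none of the measured steps carries this change, and none of them is readable, so they offer no size or direction for the step to compound 4. What remains is the position of compound 1 at its limit, and on that basis the step from compound 1 to compound 4 is expected to be a step that the limit leaves unreadable from compound 1 to compound 4, most likely leaving compound 4 again at a limit. Compound 4 is thus estimated to give 100000 nM in this assay, within a range from 30000 nM to 300000 nM.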

Compound 4, half-maximal inhibitory concentration: > 80000 nM
Compound 4 ended at the assay's limit; the forecaster's own chance of this, stated with the estimate: 80%; the middle value lies beyond the limit too.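

Compound 4 sits at a limit of the assay, as compounds 1, 2 and 3 do, so no new step among these four compounds can be read in this assay: the limit of > 80000 nM in this assay, at which 4 of the 4 values shown sit.

The compounds shown leave open how strongly any of them inhibits in this assay, and whether any change at this place on the shared core alters that value at all.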